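Swapping fluoro for methyl on the anilino ring

The source may report more compounds than this note shows. Statements on the series, on what has been measured and on what is new or still open speak of the compounds shown alone.

Compound 1, `Fc1ccc(NCCNc2ccnc3cc(Cl)ccc23)cc1`, was tested in a toxicity assay on Huh-7 cells (Homo sapiens) for cytotoxicity, read by MTT assay, with a stated time of 72 h; a higher number here means that more compound is tolerated, a lower number that less compound is tolerated. In this assay compound 1 gives > 100 ug/mL, which is a limit of the assay. Compound 2, `COc1cc(NCCNc2ccnc3cc(Cl)ccc23)cc(OC)c1`, also gives > 100 ug/mL in this assay, again a limit. Both values shown sit at the limit of > 100 ug/mL in this assay, at which 2 of the 2 values shown sit. Compound 3, `Cc1ccc(NCCNc2ccnc3cc(Cl)ccc23)cc1`, is not yet measured; it differs from compound 1 by methyl in place of fluoro on an aromatic carbon. Going by the values given here, no measured pair shows the effect of such a change, so the step that the limit leaves unreadable from compound 1 to compound 3 is expected to be none beyond the scatter. Compound 3 is estimated at 150 ug/mL, within 70 ug/mL to 300 ug/mL, and most likely reported only as a limit.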

Compound 3, half-maximal cytotoxic concentration: > 100 ug/mL
Compound 3 gave a limit, no number (the forecaster's own chance of this, stated with the estimate: 85%); the middle value is on the limit's open side.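

No step from compound 1 to compound 3 can be read, because both values are limits of the assay: the limit of > 100 ug/mL in this assay, at which 3 of the 3 values shown sit.

The compounds shown leave open the actual half-maximal cytotoxic concentration of each in this assay, and so whether fluoro and methyl differ there at all.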